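This account rests on a few compounds, and the source may have more. Where it says the series, first, only, none or still open, it means among the compounds named here.

Compound 1 `Cc1nnsc1CO/N=C/c1c(C)nn(C)c1Oc1ccccc1Cl` — in a functional assay on Huh-7 cells (Homo sapiens) for inhibition, read by MTT assay, with a stated time of 48 h (on this read-out higher numbers stand for weaker inhibition and lower numbers for stronger inhibition), compound 1 gives > 50000 nM, which is a limit of the assay.
Compound 2 `Cc1nnsc1CO/N=C/c1c(C)nn(C)c1Oc1ccc(F)cc1` — in this assay compound 2 gives > 50000 nM, likewise a limit.

Compound 2 therefore stands at the limit of this assay, and both values shown sit there, as the limit of > 50000 nM in this assay, at which 2 of the 2 values shown sit, records. Among the measured compounds shown here, the single measured step, a step that the two limits leave unreadable from compound 1 to compound 2, is of unreadable size for that reason. Compound 3 `Cc1nnsc1CO/N=C/c1c(C)nn(C)c1Oc1ccc(Br)cc1` differs from compound 2 by bromo in place of fluoro on an aromatic carbon, para to a large group. No measured step bears directly on this change, and the only step shown cannot be read, so neither a direction nor a size can be drawn from the data. Because compound 2 sits at the limit of > 50000 nM in this assay, at which 2 of the 2 values shown sit, compound 3 is expected to remain there as well, with an expected step of a number no higher from compound 2 to compound 3 (the limit leaves the size open) that does not rise beyond the scatter. Compound 3 is thus estimated at 50000 nM in this assay, within the range 20000 nM to 150000 nM, and most probably reported again only as a limit.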

Compound 3, half-maximal inhibitory concentration: 11800 nM
For compound 3 the middle estimate is 4.2-fold (0.63 log units) above the measured one; the whole stated range lies above it.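

In this assay, the swap of fluoro for bromo on an aromatic carbon, para to a large group, brings the read-out off the limit, giving an at least 4.2-fold lower number from compound 2 to compound 3 (0.62 log units; beyond the scatter). Set against the 2-chlorophenyl group, the 4-bromophenyl group likewise gives an at least 4.2-fold lower number from compound 1 to compound 3 (0.62 log units; beyond the scatter). This shows that the substituent on this phenyl ring can change the read-out beyond the scatter, but both sizes remain minimums because each step starts from a limit: the limit of > 50000 nM in this assay, at which 2 of the 3 values shown sit.

The step between the two limit compounds still cannot be read. The compounds shown leave open whether the gain is particular to bromo or would also appear with a 4-chlorophenyl, 4-methoxyphenyl or 4-aminophenyl group, and whether bromo would act in the same way elsewhere on the ring.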